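The source may hold more compounds than are shown below. What is called first, only, known or untested is meant among the compounds shown, and "the series" means these compounds.

Compound 2 `COc1cc2cc(Oc3ccc(NC(=O)Nc4ccc(C)cc4)cc3)c(C)nc2cc1OC` stands at the higher of the two numbers measured in a functional assay on MCF7 cells (Homo sapiens) for inhibition, read by sulforhodamine B assay, with a stated time of 48 h, tested at 10 uM (a higher number here means a weaker effect of the compound at the concentration tested, a lower number a stronger effect), where compound 2 gives 94.5%. Its neighbour compound 1 `COc1cc2cc(Oc3ccc(NC(=O)Nc4ccccc4)cc3)c(C)nc2cc1OC` gives 72.8% in this assay. Among the compounds with values here, the only measured step, a number 21.7 percentage points higher from compound 1 to compound 2 (beyond the scatter), went with methyl in place of hydrogen on an aromatic carbon. Compound 3 `COc1cc2cc(Oc3ccc(NC(=O)Nc4ccc(C(F)(F)F)cc4)cc3)c(C)nc2cc1OC` differs from compound 2 by trifluoromethyl in place of methyl on an aromatic carbon. Within the data shown here, that step in this assay bears on the present change only loosely, since it added a group where none was, whereas here one group replaces another at the same aromatic carbon; no measured step exchanges methyl for trifluoromethyl. With compound 2 already near the top of the scale, the step from compound 2 to compound 3 is expected to be small, a number 4.5 percentage points lower from compound 2 to compound 3 (within the scatter), with no clear direction. Compound 3 is therefore estimated at 90% in this assay, within a range from 70% to 102%.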

Compound 3, a percentage reported as activity, at one concentration (the size of the read-out at that concentration, not a potency): 84.3%
Compound 3: middle estimate off by 5.7 percentage points, on the high side; the range from low to high includes it.
By their numbers in this assay, from the lowest: compound 1; then compound 3; then compound 2.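

In this assay, what matters on this aromatic carbon is not only whether a group is present but which group it is: trifluoromethyl in place of methyl gives a number 10.2 percentage points lower from compound 2 to compound 3 (beyond the scatter), which means a stronger effect at the concentration tested. Trifluoromethyl in place of hydrogen still gives a number 11.5 percentage points higher from compound 1 to compound 3 (beyond the scatter), so neither of the two groups shown here matches the stronger effect seen with hydrogen, although they differ from each other. No measurement is available that could explain this difference between the groups.

On these data alone, it remains open whether a different group on this carbon, such as a methoxy group, a chlorine atom or an amine, would match or exceed the effect seen with hydrogen. The compounds shown also leave open whether the same ranking would hold if these groups sat on another carbon of this ring.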